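Notes on the step from compound 2 to compound 4

This account rests on a few compounds, and the source may have more. Where it says the series, first, only, none or still open, it means among the compounds named here.

Measured so far in a physicochemical assay for solubility, in phosphate buffer, measured as kinetic solubility (on this read-out higher numbers stand for higher solubility and lower numbers for lower solubility), for each compound:
- compound 1 `CC(C)[C@H](C[C@H]1CCNC1=O)c1ccc(-c2ccc3cccc(F)c3c2)[nH]c1=O` gives 26800 nM
- compound 2 `CC(C)C(c1ccc(-c2ccc3cccc(F)c3c2)[nH]c1=O)N1CCN/C1=N\C#N` gives 25200 nM
- compound 3 `CCC(CC)(c1nnc[nH]1)c1ccc(-c2ccc3cccc(F)c3c2)[nH]c1=O` gives 31200 nM

Compound 2 at 25200 nM stands within the scatter of compound 1 and compound 3, so no order can be read among the three. Compound 4 `CC(C)C(Cc1nnn[nH]1)c1ccc(-c2ccc3cccc(F)c3c2)[nH]c1=O` differs from compound 2 by a group of 6 heavy atoms (2 carbon, 4 nitrogen; one five-membered aromatic ring with 4 hetero atoms) in place of a group of 8 heavy atoms (4 carbon, 4 nitrogen; one five-membered non-aromatic ring with 2 hetero atoms), on a saturated chain carbon bound to an aromatic carbon and a saturated chain carbon and remains unmeasured. Among the measured compounds shown here, no measured pair isolates this change. The different groups of compound 1 at 26800 nM and compound 3 at 31200 nM leave both values within the scatter of compound 2, so no step beyond the scatter is expected in this assay here. The estimated step of a 1.2-fold higher number from compound 2 to compound 4 (0.08 log units; within the scatter) is expected to stay within the scatter. For compound 4 the expected value is 30000 nM with an estimated range from 16000 nM to 56000 nM in this read-out.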

Compound 4, solubility: 27300 nM
Beside the measured number, compound 4's estimate is 1.1-fold (0.04 log units) above it, and the stated range covers the measured number.
By their numbers in this assay, from the lowest: compounds 2, 1, 4 and 3 (each within the scatter of the next).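

The (1H-tetrazol-5-yl)methyl group in place of the non-aromatic ring group, on a saturated chain carbon bound to an aromatic carbon and a saturated chain carbon, gives a 1.1-fold higher number from compound 2 to compound 4 (0.03 log units; within the scatter) in this assay. Among the compounds shown here, this is the first measured pair to isolate a change at this place, and the read-out does not separate the two groups. No measurement in hand bears on why they read alike.

Still open, from the compounds shown here alone, is whether a carboxylic acid or a primary amine at this carbon would also stay within the scatter. Going by these compounds, a longer chain carrying the tetrazole is equally open.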